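Ring size on the amide nitrogen: from isopentyl to cyclohexyl

This account rests on a few compounds, and the source may have more. Where it says the series, first, only, none or still open, it means among the compounds named here.

Compound 1 `O=C(O)c1cc(-c2cccc(COc3ccc4c(c3)CN(C3CCC3)C4=O)c2)ccc1Cl`: 90 nM
Compound 2 `CC(C)CCN1Cc2cc(OCc3cccc(-c4ccc(Cl)c(C(=O)O)c4)c3)ccc2C1=O`: 60 nM

Of the compounds shown here, two have been measured in an assay on HEK293 cells for positive allosteric modulation of metabotropic glutamate receptor 2 (Rattus norvegicus), read by thallium flux; a higher number here means that more compound is needed for the effect, a lower number that less compound is needed. Compound 1 gives 90 nM, and compound 2 gives 60 nM. Within the data shown here, the only step between them, isopentyl in place of cyclobutyl on an amide-type nitrogen in a ring, is a 1.5-fold lower number from compound 1 to compound 2 (0.18 log units; within the scatter), so the two numbers cannot be told apart. Compound 2 shows the lower of the two numbers, but its nearest neighbour, compound 1, lies within the scatter of it.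

Compound 3 `O=C(O)c1cc(-c2cccc(COc3ccc4c(c3)CN(C3CCCCC3)C4=O)c2)ccc1Cl` has not yet been measured. It differs from compound 2 in one place: cyclohexyl in place of isopentyl on an amide-type nitrogen in a ring

Among the measured compounds shown here, the single measured step bears on this change, since it also swaps the group on the amide-type nitrogen in a ring, and it is a 1.5-fold lower number from compound 1 to compound 2 (0.18 log units; within the scatter). A group of similar size returned to a ring is therefore expected to leave the number within the scatter of compound 2, with no clear direction: the step from compound 2 to compound 3 in this assay is estimated as a 1.2-fold higher number from compound 2 to compound 3 (0.07 log units; within the scatter). For compound 3 the expected value in this assay is 70 nM, with a range from 30 nM to 160 nM.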

Compound 3, half-maximal effective concentration: 270 nM
Estimate against measurement, compound 3: 3.9-fold (0.59 log units) below; the whole stated range lies below it.
By their numbers in this assay, from the lowest: compounds 2 and 1 (each within the scatter of the next); then compound 3.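

In this assay the group on the amide-type nitrogen in a ring now proves able to move the number, since the exchange for cyclohexyl gives a 4.5-fold higher number from compound 2 to compound 3 (0.65 log units; beyond the scatter) and, starting from the cyclobutyl group instead, a 3.0-fold higher number from compound 1 to compound 3 (0.48 log units; beyond the scatter) with both steps clear of the scatter that left the earlier pair of compounds unresolved. Having a ring at this place does not by itself set the number, for compound 1 with its cyclobutyl ring cannot be told apart from compound 2 with its open isopentyl chain, whereas compound 3 with its cyclohexyl ring stands apart from both. The step from compound 2 to compound 3 also involves no change in hydrogen-bond donors, hydrogen-bond acceptors or net charge, so a shift of this extent at this position can arise between two groups made of carbon alone.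

Among these compounds, with only two rings at this place, it remains open whether the number rises gradually with ring size or jumps at cyclohexyl, and how a cyclopentyl group, a longer chain or a tetrahydropyranyl ring would behave. Nothing available explains why compound 3 stands apart from the other two.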